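The compounds below may be only part of what the source reports. "The series", "measured", "known", "first", "only" and "open" are said of these compounds alone.

Within the data shown here, compound 2 (`NCc1csc(NC(=O)c2cc3ccccc3n2Cc2ccccc2)n1`) gives 25 ug/mL in a physicochemical assay for solubility, read by nephelometry, measured as kinetic solubility, at pH 2.0 (on this read-out higher numbers stand for higher solubility and lower numbers for lower solubility), and holds the only true number so far. Compound 1 (`NCc1csc(NC(=O)c2cnnn2Cc2ccccc2)n1`) reads > 100 ug/mL in this assay and that entry is a limit of the assay, not a number. Compound 3 (`NCc1csc(NC(=O)c2cc3ccccc3[nH]2)n1`) departs from compound 2 in a single place: hydrogen in place of benzyl on an aromatic nitrogen, which means hydrogen in place of benzyl on an aromatic nitrogen. Among the measured compounds shown here, no measured pair here isolates a change of this kind, so any forecast for it is loose. For the measured compounds named here, the one firm reading, compound 2 at 25 ug/mL in this assay, leaves room for movement in either direction, yet a modest rise seems the likelier outcome, probably not far beyond the usual scatter. The expected change is a 2.2-fold higher number from compound 2 to compound 3 (0.34 log units; beyond the scatter) in this assay and it is only an estimate. The estimate for compound 3 is 55 ug/mL with a range of 20 ug/mL to 100 ug/mL as the expected result.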

Compound 3, solubility: > 100 ug/mL
Compound 3 was reported as a limit (the forecaster's own chance of this, stated with the estimate: 30%); middle value at least 1.8-fold (0.25 log units) from the limit.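

Putting hydrogen in place of benzyl on the aromatic nitrogen gives an at least 4.0-fold higher number from compound 2 to compound 3 (0.60 log units; beyond the scatter) in this assay. This is the first step shown that isolates a change at this position, and it shows that the reading here does not depend on keeping the benzyl. The step is only a lower bound, because the reading for compound 3 is a limit of the assay and not a number, so the real gap could be much larger: the limit of > 100 ug/mL in this assay, at which 2 of the 3 values shown sit.

Still open, going by these compounds, is whether the whole benzyl has to go, or whether a small group such as methyl on the same nitrogen would give a similar reading. A short chain ending in an amine at that place would also show whether a larger group can be kept there without the reading falling back.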